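This account rests on a few compounds, and the source may have more. Where it says the series, first, only, none or still open, it means among the compounds named here.

Measured compounds in an ADME assay on MT4 cells (Homo sapiens) for cytotoxicity; a lower number here means that less compound is tolerated, a higher number that more compound is tolerated:
- compound 1 `COC(=O)N[C@H](C(=O)NN(CCC[C@@](O)(Cc1ccccc1)C(=O)N[C@H]1c2ccccc2C[C@H]1O)Cc1ccc(F)cc1)C(C)(C)C`: > 10000 nM (a limit of the assay)
- compound 2 `COC(=O)N[C@H](C(=O)NN(CCC[C@@](O)(Cc1ccccc1)C(=O)N[C@H]1c2ccccc2C[C@H]1O)Cc1ccc(C#N)cc1)C(C)(C)C`: > 10000 nM (a limit of the assay)
- compound 3 `COC(=O)N[C@H](C(=O)NN(CCC[C@@](O)(Cc1ccccc1)C(=O)N[C@H]1c2ccccc2C[C@H]1O)Cc1ccc(-c2ccccn2)cc1)C(C)(C)C`: > 10000 nM (a limit of the assay)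

Compound 1 stands only at a limit in this assay, not at a number. Compound 2 also sits at a limit. Compound 3 also sits at a limit. This is the limit of > 10000 nM in this assay, at which 3 of the 3 values shown sit, so none of the three values shown gives a readable position.

The steps among them are accordingly unreadable: a step that the two limits leave unreadable from compound 1 to compound 2, a step that the two limits leave unreadable from compound 1 to compound 3 and a step that the two limits leave unreadable from compound 2 to compound 3. No size can be taken from any of them, in either direction.

Compound 4 `COC(=O)N[C@H](C(=O)NN(CCC[C@@](O)(Cc1ccccc1)C(=O)N[C@H]1c2ccccc2C[C@H]1O)Cc1ccc(-c2ccccc2)cc1)C(C)(C)C` is not yet measured. It differs from compound 1 as follows: phenyl in place of fluoro on an aromatic carbon. The three measured changes at the same place, to cyano and to pyridin-2-yl, left the value at the limit each time, so they bear on the step to compound 4 only as a pattern of limits, not as sizes.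

The expected step in this assay is therefore a step that the limit leaves unreadable from compound 1 to compound 4, with no direction beyond the scatter that could be read from the data. The estimate for compound 4 is 20000 nM, in the range 10000 nM to 60000 nM, most likely again reported as a limit.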

Compound 4, half-maximal cytotoxic concentration: 7500 nM
Compound 4: middle estimate off by 2.7-fold (0.43 log units), on the high side; measured number below the stated range.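

In this assay, for the compounds shown here, compound 4 gives 7500 nM, the only number at this position that is not a limit of the assay, so the series now has one readable value for the group on this aromatic carbon. The change to phenyl gives an at least 1.3-fold lower number from compound 1 to compound 4 (0.12 log units; that floor lies within the scatter), an at least 1.3-fold lower number from compound 3 to compound 4 (0.12 log units; that floor lies within the scatter) and an at least 1.3-fold lower number from compound 2 to compound 4 (0.12 log units; that floor lies within the scatter), so these floors do not establish a real difference from the fluoro, pyridin-2-yl or cyano compounds. Only floors can be read for these steps, and the steps among compound 1, compound 2 and compound 3 cannot be read at all, because those three values are limits: the limit of > 10000 nM in this assay, at which 3 of the 4 values shown sit.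

From the compounds shown here alone, how far the true values of compound 1, compound 2 and compound 3 lie from compound 4 remains open, and so does whether phenyl differs from the other groups by more than the scatter. Also open, going by these compounds, is what an amine, a carboxylic acid or a longer alkyl chain at this place would give in this assay, and whether any such group would yield a number rather than a limit.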